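This account rests on a few compounds, and the source may have more. Where it says the series, first, only, none or still open, it means among the compounds named here.

Compound 1 `Cn1ccc2c(Oc3ccc(NC(=O)c4nn(-c5ccc(Br)cc5)ccc4=O)cc3)ccnc21` gives 59400 nM in a functional assay on A549 cells (Homo sapiens) for cytotoxicity, read by MTT assay, with a stated time of 72 h; on this read-out lower numbers stand for stronger inhibition and higher numbers for weaker inhibition.
Compound 2 `Cn1ccc2c(Oc3ccc(NC(=O)c4nn(-c5ccccc5)ccc4=O)cc3)ccnc21` gives 51700 nM.
Compound 3 `Cn1ccc2c(Oc3ccc(NC(=O)c4nn(-c5ccc(Br)cc5)ccc4=O)cc3F)ccnc21` gives only a limit of the assay, > 60000 nM.

The change from compound 1 to compound 2 is hydrogen in place of bromo on an aromatic carbon and it made a 1.1-fold lower number from compound 1 to compound 2 (0.06 log units; within the scatter). Compound 3 differs from compound 1 by fluoro in place of hydrogen on an aromatic carbon; here a number no lower from compound 1 to compound 3 (the limit leaves the size open), its size hidden by the limit of > 60000 nM in this assay, at which 1 of the 3 values shown sits. Compound 4 `Cn1ccc2c(Oc3ccc(NC(=O)c4nn(-c5ccccc5)ccc4=O)cc3F)ccnc21` is not yet measured; it differs from compound 3 by hydrogen in place of bromo on an aromatic carbon, the same change as between compound 1 and compound 2, made on the core of compound 3. The step that the limit leaves unreadable from compound 3 to compound 4 is expected to be small because a 1.1-fold lower number from compound 1 to compound 2 (0.06 log units; within the scatter) lay within the scatter. Compound 4 is therefore estimated at about 65000 nM in this assay, likely between 35000 nM and 130000 nM, with a fair chance that again only a limit is reported.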

Compound 4, half-maximal inhibitory concentration: > 60000 nM
Compound 4: no number, only a limit (the forecaster's own chance of this, stated with the estimate: 60%); the middle value is on the limit's open side.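

Fluoro in place of hydrogen on the core of compound 2 gave an at least 1.1-fold higher number from compound 2 to compound 4 (0.06 log units; that floor lies within the scatter). The same change gave no lower number on either core, but the sizes of the two steps cannot be compared: the same change on two cores in this assay, a number no lower (the limit leaves the size open) from compound 1 to compound 3 and an at least 1.1-fold higher number (0.06 log units; that floor lies within the scatter) from compound 2 to compound 4; the limit leaves it open whether they differ The steps from compound 1 to compound 3 and from compound 3 to compound 4 cannot be read, so hydrogen in place of bromo shows nothing readable on the core of compound 3: the limit of > 60000 nM in this assay, at which 2 of the 4 values shown sit.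

The compounds shown leave open whether an amine or a carboxylic acid in place of bromo on the phenyl group would give a readable number in this assay. They also leave open how the fluoro change would behave on a pair of compounds whose values both stay clear of the limit.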